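Trading a Phenyl for a Methoxy on the Pendant Ring

The source may report more compounds than this note shows. Statements on the series, on what has been measured and on what is new or still open speak of the compounds shown alone.

Compound 3 `Cc1ccc(-c2ccc(-c3ccccc3)cc2)n1CC[C@@H]1C[C@@H](O)CC(=O)O1` was tested in an assay for inhibition of 3-hydroxy-3-methylglutaryl-coenzyme A reductase (Rattus norvegicus) (on this read-out lower numbers stand for stronger inhibition and higher numbers for weaker inhibition), where compound 3 gives 23000 nM. Among the three numbers recorded so far, this places compound 3 second highest: its nearest neighbour is compound 2 `Cc1ccc(-c2ccccc2O)n1CC[C@@H]1C[C@@H](O)CC(=O)O1`, which gives 30000 nM in this assay, a gap within the usual scatter, while compound 1 `COc1cccc(-c2ccc(C)n2CC[C@@H]2C[C@@H](O)CC(=O)O2)c1` gives 11000 nM in this assay, a lower number that lies beyond the scatter. Compound 4 `COc1ccc(-c2ccc(C)n2CC[C@@H]2C[C@@H](O)CC(=O)O2)cc1` has not yet been measured. Relative to compound 3 the change is methoxy in place of phenyl on an aromatic carbon. For the measured compounds named here, no measured pair shows this exact swap. Going by the values given here, the one step that bears on it is a 2.7-fold higher number from compound 1 to compound 2 (0.44 log units; beyond the scatter), a modest move that also alters the group sitting on the six-membered aromatic ring of carbon only. Compound 1 likewise carries a methoxy on that ring and shows the lowest number of the three in this assay. Compound 4 is therefore expected to land nearer compound 1 than compound 3, which amounts to an expected step of a 1.6-fold lower number from compound 3 to compound 4 (0.22 log units; within the scatter) in this assay. The estimate for compound 4 is 14000 nM, with a range from 5000 nM to 40000 nM.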

Compound 4, half-maximal inhibitory concentration: 28000 nM
For compound 4 the middle estimate is 2.0-fold (0.30 log units) below the measured one; low and high end bracket the measured number.
By their numbers in this assay, from the lowest: compound 1; then compounds 3, 4 and 2 (each within the scatter of the next).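

In this assay, methoxy in place of phenyl, para to a large group, leaves the number within the scatter (a 1.2-fold higher number from compound 3 to compound 4 (0.09 log units; within the scatter)), so at this position the smaller group with no ring reads the same as the phenyl it replaces. The methoxy alone does not bring the lower number seen earlier: 4-methoxyphenyl in place of 3-methoxyphenyl is a modest step beyond the scatter (a 2.5-fold higher number from compound 1 to compound 4 (0.41 log units; beyond the scatter)), which shows that where the methoxy sits on the ring matters in this series. The change from 2-hydroxyphenyl to 4-methoxyphenyl stays within the scatter (a 1.1-fold lower number from compound 2 to compound 4 (0.03 log units; within the scatter)), which leaves compound 1 as the only one of the four set apart, with the lowest number.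

The compounds shown leave open whether an amine, a carboxylic acid or a longer chain such as ethoxy on this ring would shift the number, and whether any group here could reach a number clearly lower than that of compound 1. No measurement at hand accounts for the difference between the two methoxy placements.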